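A few compounds are considered here, and "the series" means these few. Any claim that something is new, unique, unknown or untested is made for them only; others in the source may bear on it.

The measured compounds in a functional assay (Left cardiac atrium, Cavia porcellus), with a stated time of 30 min (on this read-out lower numbers stand for an effect already at smaller amounts and higher numbers for an effect only at larger amounts of compound), are these three: compound 1 `CC1=CSC(O)(c2ccccc2)c2noc(=O)n21` gives 230 nM; compound 2 `CC1=CSC(OCC2CCCCC2)(c2ccccc2)c2noc(=O)n21` gives 870 nM; compound 3 `COc1ccc(C2(OCC3CCCCC3)SC=C(C)n3c2noc3=O)cc1` gives 660 nM.

Compound 1 has the lowest number of the three. The step of a 3.8-fold higher number from compound 1 to compound 2 (0.58 log units; beyond the scatter) accompanies the change that, read from compound 2 back to compound 1, is hydrogen in place of cyclohexylmethyl on an oxygen on a saturated carbon; this is also how the core of compound 1 differs from the core shared by compound 2 and compound 3. From compound 2 to compound 3 the change is methoxy in place of hydrogen on an aromatic carbon, and this made a 1.3-fold lower number from compound 2 to compound 3 (0.12 log units; within the scatter).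

Compound 4 `COc1cccc(C2(O)SC=C(C)n3c2noc3=O)c1` has not yet been measured in this assay. It differs from compound 1 by methoxy in place of hydrogen on an aromatic carbon. This is the same kind of change as that from compound 2 to compound 3, not the same change: in compound 3 the methoxy stands para to a large group, in compound 4 meta to a large group, and the two pairs sit on cores that differ as told above.

For the measured compounds named here, only one measured instance of this kind of change exists, and it lies within the scatter. On that basis the step from compound 1 to compound 4 is expected to be small as well, a 1.0-fold lower number from compound 1 to compound 4 (0.02 log units; within the scatter), resting on the step from compound 2 to compound 3 and on the value of compound 1, 230 nM. Compound 4 is therefore estimated at 220 nM, expected to fall between 100 nM and 500 nM.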

Compound 4, half-maximal effective concentration: 490 nM
For compound 4 the middle estimate is 2.2-fold (0.35 log units) below the measured one; the range from low to high includes it.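

In this assay, methoxy in place of hydrogen on an aromatic carbon gave a 2.1-fold higher number from compound 1 to compound 4 (0.33 log units; beyond the scatter) on the core of compound 1, and this step does not match the one seen earlier on the other core: the same change on two cores in this assay, a 1.3-fold lower number (0.12 log units; within the scatter) from compound 2 to compound 3 and a 2.1-fold higher number (0.33 log units; beyond the scatter) from compound 1 to compound 4, 2.8-fold (0.45 log units) apart, beyond the scatter of two such steps. This shows that, in this small series, the size of the step for this kind of change cannot simply be carried from one core to the other, and a single pair on one core is a poor guide to the next. It does not show what lies behind the gap: the two pairs differ in the core, with hydrogen or cyclohexylmethyl on the oxygen, and also in where the methoxy stands, in compound 4 meta to a large group, and the compounds shown hold no pair that separates these two differences.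

The compounds shown leave open whether methoxy at one and the same place on the aromatic ring would give matching steps on both cores, and whether a step of this direction would recur with another group there, such as chlorine or a hydroxy group. They also leave open how a longer alkyl chain or an amine-bearing chain in place of the cyclohexylmethyl on the oxygen would read out.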